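The source may hold more compounds than are shown below. What is called first, only, known or untested is meant among the compounds shown, and "the series" means these compounds.

Compound 1 `COC(=O)c1nnn([C@@H]2C(=O)N(C3CCCCC3)[C@@H]2/C=C/c2ccccc2)c1C(=O)OC` gives a value in a functional assay on KB cells (Homo sapiens) for inhibition (on this read-out higher numbers stand for weaker inhibition and lower numbers for stronger inhibition), that is a limit of the assay, > 228000 nM. Compound 2 `O=C1[C@@H](n2cc(-c3ccccc3)nn2)[C@@H](/C=C/c2ccccc2)N1C1CCCCC1` gives 8360 nM. Compound 3 `COC(=O)c1nnn([C@@H]2C(=O)N(c3ccc(Cl)cc3)[C@@H]2/C=C/c2ccccc2)c1C(=O)OC` gives 145000 nM.

The change from compound 1 to compound 3, (4-chlorophenyl in place of cyclohexyl on an amide-type nitrogen in a ring), produced an at least 1.5-fold lower number from compound 1 to compound 3 (0.19 log units; that floor lies within the scatter); this step is read from a limit (the limit of > 228000 nM in this assay, at which 1 of the 3 values shown sits). The difference between the core of compound 1 and the core of compound 2 is not broken down here. Compound 2 gives the lower number of the two numbers in this assay, with a gap to compound 3 that lies beyond the scatter.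

Compound 4 `O=C1[C@@H](n2cc(-c3ccccc3)nn2)[C@@H](/C=C/c2ccccc2)N1c1ccc(Cl)cc1` carries the same change, (4-chlorophenyl in place of cyclohexyl on an amide-type nitrogen in a ring). Beside the measured step of an at least 1.5-fold lower number from compound 1 to compound 3 (0.19 log units; that floor lies within the scatter), the expected step is a 1.4-fold lower number from compound 2 to compound 4 (0.14 log units; within the scatter), resting on that earlier step being small and within the scatter. Compound 4 is expected at 6000 nM, between 2500 nM and 15000 nM.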

Compound 4, half-maximal inhibitory concentration: 84200 nM
Compound 4: middle estimate off by 14-fold (1.15 log units), on the low side, outside the stated range (above it).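

In this assay, 4-chlorophenyl in place of cyclohexyl on the amide-type nitrogen gives a 10-fold higher number from compound 2 to compound 4 (1.00 log units; beyond the scatter), so the change did not carry from one core to the other as a step of the same size: the same change on two cores in this assay, an at least 1.5-fold lower number (0.19 log units; that floor lies within the scatter) from compound 1 to compound 3 and a 10-fold higher number (1.00 log units; beyond the scatter) from compound 2 to compound 4, at least 15-fold (1.19 log units) apart, beyond the scatter of two such steps. The value of compound 1 is a limit, so the earlier step gives only a floor and not its true size: the limit of > 228000 nM in this assay, at which 1 of the 4 values shown sits. Among these compounds, with only two pairs, this shows that the outcome of the change differs between these two cores, but not which feature of the cores lies behind that difference or how a further core would behave.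

The compounds shown leave open how an unsubstituted phenyl or a benzyl group on the same nitrogen would compare on the core of compound 2. They also leave open whether a carboxylic acid or an amine on the aryl ring would change the result.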